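Adding a methyl to the amine: a small change tested

A few compounds are considered here, and "the series" means these few. Any claim that something is new, unique, unknown or untested is made for them only; others in the source may bear on it.

Compound 1 `COc1cc[nH]c1/C=C1\C(=O)Nc2ccc(F)c(C#C[C@H](N)CO)c21` is measured in a functional assay on MDA-MB-435 cells (Homo sapiens) for inhibition (a lower number here means a stronger inhibitor, a higher number a weaker inhibitor), and gives 320 nM. Compound 2 `CN[C@@H](C#Cc1c(F)ccc2c1/C(=C/c1[nH]ccc1OC)C(=O)N2)CO` carries methyl in place of hydrogen on an amine nitrogen and in this assay compound 2 gives 300 nM, so that a 1.1-fold lower number from compound 1 to compound 2 (0.03 log units; within the scatter). Compound 3 `COc1cc[nH]c1/C=C1\C(=O)Nc2ccc(F)c(C#C[C@@H](N)[C@@H](C)O)c21` differs from compound 1 by 1-amino-2-hydroxypropyl in place of 1-amino-2-hydroxyethyl on a triple-bonded carbon; in this assay compound 3 gives 300 nM, and a 1.1-fold lower number from compound 1 to compound 3 (0.03 log units; within the scatter). Between the two, no change at the digits printed from compound 2 to compound 3 (within the scatter). Compound 4 `CN[C@H](C#Cc1c(F)ccc2c1/C(=C/c1[nH]ccc1OC)C(=O)N2)[C@@H](C)O` is not yet measured; it differs from compound 3 by methyl in place of hydrogen on an amine nitrogen, the same change already seen from compound 1 to compound 2, at the same place. The expected step is a 1.1-fold lower number from compound 3 to compound 4 (0.03 log units; within the scatter) because a 1.1-fold lower number from compound 1 to compound 2 (0.03 log units; within the scatter) lay within the scatter, and that single measured example is all the change rests on. Compound 4 is therefore estimated at 280 nM, with a likely range between 140 nM and 560 nM.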

Compound 4, half-maximal inhibitory concentration: 358 nM
Beside the measured number, compound 4's estimate is 1.3-fold (0.11 log units) below it; the measured number falls inside the stated range.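

Methyl in place of hydrogen on the amine nitrogen of compound 3 gives a 1.2-fold higher number from compound 3 to compound 4 (0.08 log units; within the scatter) and the other two new steps also stay within the scatter: a 1.2-fold higher number from compound 2 to compound 4 (0.08 log units; within the scatter) and a 1.1-fold higher number from compound 1 to compound 4 (0.05 log units; within the scatter). In this assay the change reads alike on both cores: the same change on two cores in this assay, a 1.1-fold lower number (0.03 log units; within the scatter) from compound 1 to compound 2 and a 1.2-fold higher number (0.08 log units; within the scatter) from compound 3 to compound 4, 1.3-fold (0.10 log units) apart, within the scatter of two such steps. This shows that the methyl carried over without a measurable shift in these two pairs, but it does not show that the methyl has any effect of its own, nor that the match would hold on a further core or in a different assay.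

The compounds shown leave open what a longer chain on the amine nitrogen, such as ethyl or propyl, would do in this series.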